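Thioether series: cytotoxicity limits, compound 4 pending

The compounds below may be only part of what the source reports. "The series", "measured", "known", "first", "only" and "open" are said of these compounds alone.

Compound 1 `C#CCSc1nnc(CC)n1N1C(=O)c2ccccc2C1=O`: in a functional assay on HepG2 cells (Homo sapiens) for cytotoxicity, read by MTT assay, with a stated time of 48 h (on this read-out higher numbers stand for weaker inhibition and lower numbers for stronger inhibition), compound 1 gives > 200000 nM, a limit of the assay rather than a number.
Compound 2 `CCc1nnc(SCC(=O)c2ccccc2)n1N1C(=O)c2ccccc2C1=O`: compound 2 gives > 200000 nM, also a limit.
Compound 3 `CCc1nnc(SCC(=O)c2ccc(Cl)cc2)n1N1C(=O)c2ccccc2C1=O`: compound 3 gives > 200000 nM, again a limit.

Compound 3 therefore stands only at a limit, as do the two other measured members; the shared feature is the limit of > 200000 nM in this assay, at which 3 of the 3 values shown sit. The step that the two limits leave unreadable from compound 1 to compound 2, the step that the two limits leave unreadable from compound 1 to compound 3 and the step that the two limits leave unreadable from compound 2 to compound 3 all lie between two limits, so no size can be assigned to any of them, and no direction can be read.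

Compound 4 `CCc1nnc(SCC(=O)c2ccc(C)cc2)n1N1C(=O)c2ccccc2C1=O` differs from compound 3 by methyl in place of chloro on an aromatic carbon. Among the measured compounds shown here, the only measured change on the same aromatic ring is a step that the two limits leave unreadable from compound 2 to compound 3, which likewise yields no readable size. For the measured compounds named here, no measured step supports a shift beyond the scatter in either direction, and the working expectation is that compound 4 again sits at the limit. For compound 4 the estimate is 200000 nM, with a range of 80000 nM to 500000 nM. The expected step is a number no higher from compound 3 to compound 4 (the limit leaves the size open), estimated as no change beyond the scatter.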

Compound 4, half-maximal inhibitory concentration: > 200000 nM
Compound 4 gave a limit, no number (the forecaster's own chance of this, stated with the estimate: 85%); the middle value lies on the limit itself.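

No new step can be read: in this assay, the steps from compound 1, compound 2 and compound 3 to compound 4 all lie between two limits, so they have neither size nor direction. The compounds shown leave open whether any change to the shared core gives a readable number, since all remain at one limit: the limit of > 200000 nM in this assay, at which 4 of the 4 values shown sit.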